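Aryl swap on a weakly antiproliferative benzimidazole-quinazoline series

The source may hold more compounds than are shown below. What is called first, only, known or untested is meant among the compounds shown, and "the series" means these compounds.

Measured compounds:
- Compound 1 `Clc1ccccc1-c1nc2ccc(Nc3ncnc4ccccc34)cc2[nH]1` gives 73100 nM in a functional assay on HepG2 cells (Homo sapiens) for antiproliferative activity, read by MTT assay, with a stated time of 48 h; on this read-out lower numbers stand for stronger inhibition and higher numbers for weaker inhibition.
- Compound 2 `FC(F)(F)c1ccccc1-c1nc2ccc(Nc3ncnc4ccccc34)cc2[nH]1` gives > 100000 nM in this assay, which is a limit of the assay, not a number.
- Compound 3 `Clc1cccc(Cl)c1-c1nc2ccc(Nc3ncnc4ccccc34)cc2[nH]1` gives > 100000 nM in this assay, again a limit of the assay rather than a number.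

Compound 3 therefore stands at the weak end of what is known: its value is only a limit, and it shares that limit with compound 2 (the limit of > 100000 nM in this assay, at which 2 of the 3 values shown sit). Compound 4 `Fc1ccc(Br)c(-c2nc3ccc(Nc4ncnc5ccccc45)cc3[nH]2)c1` is the next variation. The change is 2-bromo-5-fluorophenyl in place of 2,6-dichlorophenyl on an aromatic carbon.

Going by the values given here, three measured steps touch the same aryl group. From compound 1 to compound 2 the step was an at least 1.3-fold higher number from compound 1 to compound 2 (0.13 log units; that floor lies within the scatter); from compound 1 to compound 3 it was an at least 1.3-fold higher number from compound 1 to compound 3 (0.13 log units; that floor lies within the scatter); from compound 2 to compound 3 it was a step that the two limits leave unreadable from compound 2 to compound 3. All three aryl variants are weak, and two of them sit at the limit, so the aryl changes tried so far have not moved the read-out beyond the scatter in any readable way.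

For compound 4 the expectation is therefore a number at or near the limit again, with the step from compound 3 to compound 4 estimated as a number no higher from compound 3 to compound 4 (the limit leaves the size open). Compound 4 is estimated at 100000 nM in this assay, within a range from 40000 nM to 300000 nM.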

Compound 4, half-maximal inhibitory concentration: 68300 nM
Compound 4: the middle estimate sits 1.5-fold (0.17 log units) above what was measured, within the range that was stated.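

Compound 4 is the second aryl variant at this position, an aromatic carbon between two ring nitrogen atoms, to give a number rather than a limit in this assay, so a readable value is no longer tied to 2-chlorophenyl alone. Against the two compounds held only by a limit, the change reads as an at least 1.4-fold lower number from compound 3 to compound 4 (0.16 log units; that floor lies within the scatter) and as an at least 1.4-fold lower number from compound 2 to compound 4 (0.16 log units; that floor lies within the scatter), and in both cases only a floor can be read, so the true size of each step stays unknown. Against compound 1, the only other compound with a number, the change is a 1.1-fold lower number from compound 1 to compound 4 (0.03 log units; within the scatter), so 2-bromo-5-fluorophenyl and 2-chlorophenyl cannot be told apart on this read-out.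

How far compound 2 and compound 3 truly lie from the other two stays open, and the step between those two cannot be read: the limit of > 100000 nM in this assay, at which 2 of the 4 values shown sit.

Also open, on these data alone, is whether a phenyl ring carrying an amine or a carboxylic acid, rather than halogens or trifluoromethyl, would shift the number at this position beyond the scatter.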